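Sulfonamide series: halogen versus butoxy on the aniline ring

The source may hold more compounds than are shown below. What is called first, only, known or untested is meant among the compounds shown, and "the series" means these compounds.

Measured so far:
compound 1, `O=C1NCCN1c1ccc(S(=O)(=O)Nc2cccc(Br)c2)cc1`, 77 nM
compound 2, `CCCCOc1ccc(NS(=O)(=O)c2ccc(N3CCNC3=O)cc2)cc1`, 630 nM

The two compounds share one core and differ only in the substituent on the aniline ring. In a functional assay on HT-29 cells (Homo sapiens) for antiproliferative activity, read by sulforhodamine B assay, with a stated time of 48 h (on this read-out higher numbers stand for weaker inhibition and lower numbers for stronger inhibition), compound 1 gives 77 nM and compound 2 gives 630 nM. Compound 2 therefore stands highest of the two numbers; its nearest neighbour is compound 1, whose number is lower by a gap well beyond the scatter, so compound 2 is the weaker inhibitor of the pair.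

Compound 3, `O=C1NCCN1c1ccc(S(=O)(=O)Nc2ccc(I)cc2)cc1`, is not yet measured. Relative to compound 2 the change is iodo in place of butoxy on an aromatic carbon; the iodo group sits para to a large group. Going by the values given here, no step between measured compounds with the same change exists, so the expectation for compound 3 rests on the halogen-bearing compound 1 alone. Since compound 1 gives 77 nM, compound 3 is expected to come in well below compound 2, a downward step a 5.7-fold lower number from compound 2 to compound 3 (0.76 log units; beyond the scatter) beyond the scatter. The estimate for compound 3 in this assay is 110 nM, with a range from 30 nM to 450 nM.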

Compound 3, half-maximal inhibitory concentration: 650 nM
Estimate against measurement, compound 3: 5.9-fold (0.77 log units) below, outside the stated range (above it).
By their numbers in this assay, from the lowest: compound 1; then compounds 2 and 3 (each within the scatter of the next).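

In this assay, iodo in place of butoxy on an aromatic carbon para to a large group reads as a step of a 1.0-fold higher number from compound 2 to compound 3 (0.01 log units; within the scatter), so a single iodine atom and a butoxy group of 5 heavy atoms cannot be told apart at this place, and compounds 2 and 3 sit level with each other. A halogen on the ring attached to the sulfonamide nitrogen therefore does not by itself bring the low number of compound 1, since 4-iodophenyl in place of 3-bromophenyl gives an 8.4-fold higher number from compound 1 to compound 3 (0.93 log units; beyond the scatter) and compound 1 stands alone at the low end of the three. Nothing at hand bears on the reason for either step.

The 4-iodophenyl for 3-bromophenyl step changes both the halogen and its place at once, so the compounds shown cannot say which of the two carries the gap, and 4-bromophenyl and 3-iodophenyl are the groups that would separate them. Going by these compounds, how a methoxy group, an amine or a carboxylic acid would read para to a large group also stays open, so the match between iodo and butoxy holds for this pair alone.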